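Swapping methoxy for hydrogen in a weakly toxic pair

This account rests on a few compounds, and the source may have more. Where it says the series, first, only, none or still open, it means among the compounds named here.

Compound 1 `N#C[C@H]1[C@H](O)[C@@H](CO)O[C@H]1n1cnc2c(Cl)nc(N)nc21` and compound 2 `COc1nc(N)nc2c1ncn2[C@@H]1O[C@H](CO)[C@@H](O)[C@@H]1C#N` share a core, and both were tested in an ADME assay on DG-75 cells (Homo sapiens) for cytotoxicity, read by MTT assay, with a stated time of 120 h; a higher number here means a weaker inhibitor, a lower number a stronger inhibitor. Compound 1 gives > 15000 nM, which is a limit of the assay and not a number. Compound 2 gives > 15000 nM, which is also a limit. The whole picture so far is therefore (the limit of > 15000 nM in this assay, at which 2 of the 2 values shown sit).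

Compound 3 `N#C[C@H]1[C@H](O)[C@@H](CO)O[C@H]1n1cnc2cnc(N)nc21` differs from compound 2 by a single change, hydrogen in place of methoxy on an aromatic carbon.

Going by the values given here, the one measured step that bears on this change is a step that the two limits leave unreadable from compound 1 to compound 2, with methoxy in place of chloro on an aromatic carbon. Its size cannot be read, so it offers no direction. Neither compound, however, gave a number in this assay, and nothing shown points to hydrogen behaving differently. With compound 2 at > 15000 nM, the expected move is a step that the limit leaves unreadable from compound 2 to compound 3, which means no step beyond the usual scatter in either direction.

Compound 3 is estimated at 20000 nM, with an expected range from 10000 nM to 40000 nM, and the assay will quite likely report only a limit again.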

Compound 3, half-maximal inhibitory concentration: > 15000 nM
Compound 3 was reported as a limit (the forecaster's own chance of this, stated with the estimate: 85%); the middle value is on the limit's open side.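

Compound 3 gives > 15000 nM as a limit of the assay and not a number. Going by these compounds alone, no step among compound 1, compound 2 and compound 3 can be read, because all three values are limits: the limit of > 15000 nM in this assay, at which 3 of the 3 values shown sit. The compounds shown leave open how far each lies beyond that limit, and whether chloro, methoxy or hydrogen on this aromatic carbon makes any difference in this assay.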